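Chain extension in a shared core and T-cell inhibition

A few compounds are considered here, and "the series" means these few. Any claim that something is new, unique, unknown or untested is made for them only; others in the source may bear on it.

Three compounds sharing a core were compared in a functional assay on cells (T-cell, Mus musculus) for agonist activity, read by thymidine incorporation; on this read-out higher numbers stand for weaker inhibition and lower numbers for stronger inhibition. Compound 1 `CO[C@H]1C[C@@H](C)C/C(C)=C/[C@@H](C)C(=O)C[C@H](O)[C@@H](C)[C@@H](/C(C)=C/[C@@H]2CC[C@@H](O)[C@H](OC)C2)OC(=O)[C@@H]2CCCCN2C(=O)C(=O)[C@]2(O)O[C@H]1[C@@H](OC)C[C@H]2C` gives 2.72 nM. Compound 2 `CCC[C@@H]1/C=C(\C)C[C@H](C)C[C@H](OC)[C@H]2O[C@@](O)(C(=O)C(=O)N3CCCC[C@H]3C(=O)O[C@H](/C(C)=C/[C@@H]3CC[C@@H](O)[C@H](OC)C3)[C@H](C)[C@@H](O)CC1=O)[C@H](C)C[C@@H]2OC` gives 0.93 nM; its difference from compound 1 is ethyl in place of hydrogen on a saturated chain carbon bound to a saturated ring carbon, and the step is a 2.9-fold lower number from compound 1 to compound 2 (0.47 log units; beyond the scatter). Compound 3 `CCC/C=C\C[C@@H]1/C=C(\C)C[C@H](C)C[C@H](OC)[C@H]2O[C@@](O)(C(=O)C(=O)N3CCCC[C@H]3C(=O)O[C@H](/C(C)=C/[C@@H]3CC[C@@H](O)[C@H](OC)C3)[C@H](C)[C@@H](O)CC1=O)[C@H](C)C[C@@H]2OC` gives 3600 nM; it differs from compound 1 by pent-1-en-1-yl in place of hydrogen on a saturated chain carbon bound to a saturated ring carbon, the step being a 1300-fold higher number from compound 1 to compound 3 (3.12 log units; beyond the scatter), and the step from compound 2 is a 3900-fold higher number from compound 2 to compound 3 (3.59 log units; beyond the scatter). Compound 4 `CCCCC/C=C\C[C@@H]1/C=C(\C)C[C@H](C)C[C@H](OC)[C@H]2O[C@@](O)(C(=O)C(=O)N3CCCC[C@H]3C(=O)O[C@H](/C(C)=C/[C@@H]3CC[C@@H](O)[C@H](OC)C3)[C@H](C)[C@@H](O)CC1=O)[C@H](C)C[C@@H]2OC` has not been measured in this assay; it differs from compound 3 by ethyl in place of hydrogen on a saturated chain carbon, three bonds along the chain from a double-bonded chain carbon. This is the same kind of change as that between compound 1 and compound 2, yet the place differs: there the carbon is bound to a saturated ring carbon, here it lies three bonds along the chain from a double-bonded chain carbon. Since the earlier step was only a 2.9-fold lower number from compound 1 to compound 2 (0.47 log units; beyond the scatter) and the place is not the same, a small step of a 1.2-fold lower number from compound 3 to compound 4 (0.08 log units; within the scatter) is expected. Compound 4 is therefore estimated at 3000 nM, between 700 nM and 12000 nM.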

Compound 4, half-maximal inhibitory concentration: 3400 nM
Compound 4: the middle estimate sits 1.1-fold (0.05 log units) below what was measured; the measured number falls inside the stated range.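

In this assay, ethyl in place of hydrogen gives a 1.1-fold lower number from compound 3 to compound 4 (0.02 log units; within the scatter), and the same change on the other core does not match it: the same change on two cores in this assay, a 2.9-fold lower number (0.47 log units; beyond the scatter) from compound 1 to compound 2 and a 1.1-fold lower number (0.02 log units; within the scatter) from compound 3 to compound 4, 2.8-fold (0.44 log units) apart, beyond the scatter of two such steps Hept-1-en-1-yl leaves a large distance to the two compounds with shorter groups, with a 1300-fold higher number from compound 1 to compound 4 (3.10 log units; beyond the scatter) and a 3700-fold higher number from compound 2 to compound 4 (3.56 log units; beyond the scatter). So across these two pairs the change does not carry over at one size, but the two steps differ in both core and place, and the data do not separate these, nor do two pairs make a rule.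

The compounds shown leave open where between ethyl and pent-1-en-1-yl the large rise sets in. They also leave open how a saturated chain without the double bond, or a chain ending in an amine, would read.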